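The compounds below may be only part of what the source reports. "The series", "measured", "known", "first", "only" and "open" are said of these compounds alone.

Working notes on the series. Three measured compounds share one core and differ only in the group on an aromatic carbon of it. Compound 1 `O=C(O)Cc1sc(C(c2ccc(F)cc2)c2ccc(F)cc2)nc1-c1ccc(Cl)cc1` gives 80% in an in vitro functional assay on HEK285-7 cells for antagonist activity at prostaglandin D2 receptor 2 (Homo sapiens), read by BRET and beta-arrestin recruitment; on this read-out higher numbers stand for larger maximal responses and lower numbers for smaller maximal responses. Compound 2 `O=C(O)Cc1sc(C(c2ccc(F)cc2)c2ccc(F)cc2)nc1-c1ccnc(F)c1` gives 80% in this assay, and compound 3 `O=C(O)Cc1sc(C(c2ccc(F)cc2)c2ccc(F)cc2)nc1-c1ccoc1` gives 80% in this assay. The steps among them read: no change at the digits printed from compound 1 to compound 2 (within the scatter); no change at the digits printed from compound 1 to compound 3 (within the scatter); no change at the digits printed from compound 2 to compound 3 (within the scatter). Compound 3 thus stands level with compound 1 and compound 2 at the digits shown, and no order can be read among the three.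

Compound 4 `O=C(O)Cc1sc(C(c2ccc(F)cc2)c2ccc(F)cc2)nc1-c1ccccc1` has not yet been measured. Its difference from compound 3 is phenyl in place of furan-3-yl on an aromatic carbon. Each of the three measured steps swaps one aromatic group for another on the same aromatic carbon of the shared core, and each stays within the scatter, so all three bear on the present change, though none swaps exactly this pair of groups. The expectation is therefore no step beyond the scatter in this assay.

The step expected from compound 3 to compound 4 is no change at the digits printed from compound 3 to compound 4 (within the scatter). Compound 4 is estimated at 80% in this assay. For compound 4 the expected range runs from 68% to 92%.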

Compound 4, largest response reached (reported as efficacy), in percent of the reference or control that the assay uses: 80%
For compound 4 middle estimate and measured number coincide at the digits printed, and the stated range covers the measured number.
By their numbers in this assay, from the lowest: compounds 1, 2, 3 and 4 (each within the scatter of the next).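

In this assay, the swap of furan-3-yl for phenyl on this aromatic carbon, next to the ring nitrogen, gives no change at the digits printed from compound 3 to compound 4 (within the scatter) and the swap of 2-fluoropyridin-4-yl for phenyl gives no change at the digits printed from compound 2 to compound 4 (within the scatter), so among the groups shown, a six-membered aromatic ring of carbon only with no further group on it sits level with the rings that hold a hetero atom. Within the data shown here, the step with hydrogen in place of chloro, which reads no change at the digits printed from compound 1 to compound 4 (within the scatter), is the first that removes a single atom from the aromatic group instead of exchanging one whole ring for another, and it shows that the chloro group of compound 1 is not needed to hold the maximal response at this level. No supporting data bear on why the response stays level across these four compounds.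

What a saturated ring such as cyclohexyl, an amine or a carboxylic acid would do on this same carbon stays open, since all the groups shown are aromatic rings. Also open, as far as these compounds go, is whether the level response would hold if the carboxymethyl group or the large group on the neighbouring ring atoms were exchanged.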